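A few compounds are considered here, and "the series" means these few. Any claim that something is new, unique, unknown or untested is made for them only; others in the source may bear on it.

Measured compounds:
compound 1, `COc1ccc(C(=O)NC[C@H]2c3[nH]c4ccccc4c3C[C@H]3[C@H]4c5[nH]c6ccccc6c5C[C@@H]([C@H](C#N)N23)N4C)cc1`: 840 nM
compound 2, `CN1[C@@H]2c3[nH]c4ccccc4c3C[C@H]1[C@H](C#N)N1[C@@H](CNC(=O)c3cc4ccccc4o3)c3[nH]c4ccccc4c3C[C@@H]21`: 850 nM

Both were tested in a functional assay on HT-29 cells (Homo sapiens) for cytotoxicity, read by MTT assay, with a stated time of 72 h; a higher number here means a weaker inhibitor, a lower number a stronger inhibitor. Compound 1 gives 840 nM there and compound 2 gives 850 nM; the step of a 1.0-fold higher number from compound 1 to compound 2 (0.01 log units; within the scatter) is within the scatter, so the two compounds cannot be told apart on these numbers. Compound 3, `CN1[C@@H]2c3[nH]c4ccccc4c3C[C@H]1[C@H](C#N)N1[C@@H](CNC(=O)/C=C/c3ccccc3)c3[nH]c4ccccc4c3C[C@@H]21`, has not yet been measured. It differs from compound 2 in one place: 2-phenylethenyl in place of 1-benzofuran-2-yl on a carbonyl carbon. Within the data shown here, the only measured step that bears on this position is the exchange of one aromatic group for another on the same carbonyl carbon, a 1.0-fold higher number from compound 1 to compound 2 (0.01 log units; within the scatter), which produced no shift beyond the scatter. With nothing pointing in either direction, compound 3 is expected to give a number close to that of compound 2, and the step of no change at the digits printed from compound 2 to compound 3 (within the scatter) is estimated to stay within the scatter. The value expected for compound 3 in this assay is 850 nM, with a range from 400 nM to 1800 nM.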

Compound 3, half-maximal inhibitory concentration: 1400 nM
Compound 3: the middle estimate sits 1.6-fold (0.22 log units) below what was measured, within the range that was stated.
By their numbers in this assay, from the lowest: compounds 1, 2 and 3 (each within the scatter of the next).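

In this assay, the position now holds a third group, one with a double bond outside aromatic rings, a single six-membered aromatic ring and no oxygen atom. Placing 2-phenylethenyl on the carbonyl carbon in place of 1-benzofuran-2-yl gives a 1.6-fold higher number from compound 2 to compound 3 (0.22 log units; within the scatter), and placing it there in place of 4-methoxyphenyl gives a 1.7-fold higher number from compound 1 to compound 3 (0.22 log units; within the scatter), so none of the three compounds can be told apart on these numbers. Nothing measured here offers an explanation for this result.

On these data alone, all three groups carry an aromatic ring, so it remains open whether a saturated 2-phenylethyl group, a simple alkyl chain or a group bearing an amine or a carboxylic acid on this carbonyl carbon would move the number beyond the scatter. The compounds shown also leave open whether this holds in any other cell line.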